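The compounds below may be only part of what the source reports. "The series", "measured", "known", "first", "only" and "open" are said of these compounds alone.

Values in a functional assay on RPMI-8226 cells (Homo sapiens) for antiproliferative activity, read by radiometric assay, with a stated time of 72 h; a lower number here means a stronger inhibitor, a higher number a weaker inhibitor:
- compound 1 `O=C(CCCCCCC(=O)Nc1cc2ncnc(Nc3ccc(Cl)cc3F)c2s1)NO`: 1900 nM
- compound 2 `Cc1ccc(F)c(Nc2ncnc3cc(NC(=O)CCCCCCC(=O)NO)sc23)c1`: 1060 nM
- compound 3 `COc1ccc(Nc2ncnc3cc(NC(=O)CCCCCCC(=O)NO)sc23)c(C)c1`: not yet measured

Compound 2 sits within the scatter of compound 1, so it holds no distinct rank. Compound 3 differs from compound 2 as follows: 4-methoxy-2-methylphenyl in place of 2-fluoro-5-methylphenyl on a nitrogen on an aromatic ring. For the measured compounds named here, one measured step bears on this change, with a swap of the group at the same place: a 1.8-fold lower number from compound 1 to compound 2 (0.25 log units; within the scatter). That step stayed within the scatter, so no shift beyond the scatter is expected in this assay. The expected step is a 1.1-fold higher number from compound 2 to compound 3 (0.05 log units; within the scatter). For compound 3 the estimated value is 1200 nM, with an expected range of 500 nM to 3000 nM.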

Compound 3, half-maximal inhibitory concentration: 1980 nM
Compound 3: the middle estimate sits 1.7-fold (0.22 log units) below what was measured; low and high end bracket the measured number.
By their numbers in this assay, from the lowest: compounds 2, 1 and 3 (each within the scatter of the next).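

In this assay the step to 4-methoxy-2-methylphenyl reads a 1.9-fold higher number from compound 2 to compound 3 (0.27 log units; within the scatter) and, from 4-chloro-2-fluorophenyl, a 1.0-fold higher number from compound 1 to compound 3 (0.02 log units; within the scatter), so neither step separates the three compounds. On this nitrogen, a ring carrying methoxy and methyl and no halogen therefore gives a number within the scatter of both halogen-bearing rings. No measurement on hand explains these numbers.

From the compounds shown here alone, whether any group at this position moves the number beyond the scatter remains open, as all three rings are phenyl rings with neutral groups. An amine or a carboxylic acid on the ring, or a pyridine ring in its place, would test this.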